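Halogens Weakened Compound 1; A Methyl Is Untested

This account rests on a few compounds, and the source may have more. Where it says the series, first, only, none or still open, it means among the compounds named here.

Within the data shown here, compound 1 `CC1=NN(c2ccccc2)C(=O)C12C=CC(=O)C=C2c1ccccc1` is the one compound here with a measured number: in a functional assay on HCT-116 cells (Homo sapiens) for antiproliferative activity, read by CCK-8 assay, with a stated time of 72 h (on this read-out lower numbers stand for stronger inhibition and higher numbers for weaker inhibition), compound 1 gives 17800 nM. Compound 2 `CC1=NN(c2ccc(Br)cc2)C(=O)C12C=CC(=O)C=C2c1ccccc1` carries bromo in place of hydrogen on an aromatic carbon; in this assay compound 2 reaches only a limit of the assay, > 100000 nM. Compound 3 `CC1=NN(c2ccc(Cl)cc2)C(=O)C12C=CC(=O)C=C2c1ccccc1` carries chloro in place of hydrogen on an aromatic carbon; in this assay compound 3 also reaches only a limit, > 100000 nM. Both additions read as weakening: an at least 5.6-fold higher number from compound 1 to compound 2 (0.74 log units; beyond the scatter) and an at least 5.6-fold higher number from compound 1 to compound 3 (0.74 log units; beyond the scatter). The step between the two halogen compounds cannot be read, a step that the two limits leave unreadable from compound 2 to compound 3, since both sit at the limit of > 100000 nM in this assay, at which 2 of the 3 values shown sit.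

Compound 4 `CC1=NN(c2ccccc2)C(=O)C12C=CC(=O)C=C2c1ccc(C)cc1` differs from compound 1 by methyl in place of hydrogen on an aromatic carbon. The two measured steps each added a halogen and each weakened the compound beyond the scatter, but neither added a methyl, so they give only a loose guide. A weakening is expected for compound 4, of a size a 1.7-fold higher number from compound 1 to compound 4 (0.23 log units; within the scatter). Compound 4 is therefore estimated at 30000 nM, within a range from 10000 nM to 100000 nM.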

Compound 4, half-maximal inhibitory concentration: 27100 nM
For compound 4 the middle estimate is 1.1-fold (0.04 log units) above the measured one, and the stated range covers the measured number.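

The change from phenyl to 4-methylphenyl gives a 1.5-fold higher number from compound 1 to compound 4 (0.18 log units; within the scatter) in this assay, and so the two compounds cannot be told apart. Among these compounds, the earlier steps placed halogens on the other phenyl of the core, so this is the first reading on this ring, and it shows that a single methyl, para to a large group, can be added here without a readable loss of activity. Nothing measured here offers a reason for this result.

On these data alone, one small group says little about larger or different ones, so the outcome at this position with an amine, a carboxylic acid or a longer chain stays open. As far as these compounds go, it is also open whether chloro or bromo on this ring would give the same result as methyl or would match the halogen steps on the other phenyl.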